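The source may report more compounds than this note shows. Statements on the series, on what has been measured and on what is new or still open speak of the compounds shown alone.

Series notes. Two members of the series have a reading so far. Compound 1 `Cc1ccc(Nc2cc(NC(=O)Nc3c(Cl)cccc3Cl)ncn2)cc1C` gives, in a functional assay on NCI-H1581 cells (Homo sapiens) for inhibition, read by MTT assay, with a stated time of 48 h, tested at 10 uM (a lower number here means less inhibition, a higher number more inhibition at the concentration tested (going by the name of the read-out)), a value of 73.3%. Compound 2 `COc1cc(NC(=O)Nc2cc(Nc3ccc(C)c(C)c3)ncn2)cc(OC)c1` gives in this assay a value of 20.1%. Compound 2 thus holds the lower of the two numbers; its gap to compound 1 lies beyond the usual scatter of the read-out. For the measured compounds named here, no pair that differs in a single place has been measured, so no single step has a known size here.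

Compound 3 `COc1cc(NC(=O)Nc2cc(Nc3cc(F)ccc3OC)ncn2)cc(OC)c1` is the next member and awaits its reading in this assay. It keeps the urea side of compound 2 and differs from it in one place: 5-fluoro-2-methoxyphenyl in place of 3,4-dimethylphenyl on a nitrogen on an aromatic ring. Going by the values given here, no measured pair shows what this exchange does, so the expectation rests only on the low reading of compound 2 in this assay, namely 20.1%, with a wide margin. The step from compound 2 to compound 3 is expected to be small, a number 5.9 percentage points higher from compound 2 to compound 3 (within the scatter), and not clearly beyond the scatter in either direction. Compound 3 is estimated at 26%, within a range of 5% to 55%.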

Compound 3, a percentage reported as inhibition, at one concentration (the size of the read-out at that concentration, not a potency): 42.1%
Estimate against measurement, compound 3: 16.1 percentage points below, and the stated range covers the measured number.
By their numbers in this assay, from the lowest: compound 2; then compound 3; then compound 1.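

For the compounds shown here, the aromatic group on this nitrogen is the first position with a measured single change. In this assay, 5-fluoro-2-methoxyphenyl in place of 3,4-dimethylphenyl gives a number 22 percentage points higher from compound 2 to compound 3 (beyond the scatter) with the urea side held constant, so the reading responds to this group. No measured property bears on this step and the entering group differs from the leaving group in more than one feature, so the step cannot be assigned to the fluoro or the methoxy part.

The compounds shown leave open whether a plain 2-methoxyphenyl or a plain 3-fluorophenyl would carry the same step, and how a group such as a carboxylic acid or an amine would read here. They also leave open whether the exchange has a step of similar size on the urea side of compound 1.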